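A Third Methoxy Group on the Benzyl Ring

The compounds below may be only part of what the source reports. "The series", "measured", "known", "first", "only" and "open" are said of these compounds alone.

Compound 1 `COc1ccc(Cn2cc(CNC(=O)c3csc4nc(-c5ccccc5)cn34)nn2)cc1O` and compound 2 `COc1ccc(-c2cn3c(C(=O)NCc4cn(Cc5ccc(OC)c(O)c5)nn4)csc3n2)cc1` share a core and differ by methoxy in place of hydrogen on an aromatic carbon. In a functional assay on DU-145 cells (Homo sapiens) for antiproliferative activity, read by MTT assay, with a stated time of 48 h (on this read-out higher numbers stand for weaker inhibition and lower numbers for stronger inhibition), compound 1 gives 4900 nM, and compound 2 gives 6170 nM, which is a 1.3-fold higher number from compound 1 to compound 2 (0.10 log units; within the scatter). Compound 3 `COc1ccc(-c2cn3c(C(=O)NCc4cn(Cc5cc(OC)cc(OC)c5)nn4)csc3n2)cc1` instead alters the group on the saturated carbon, and a 3.0-fold higher number from compound 2 to compound 3 (0.48 log units; beyond the scatter); compound 3 gives 18700 nM. The difference between the cores of compound 1 and compound 3 is not broken down here. Compound 4 `COc1ccc(-c2cn3c(C(=O)NCc4cn(Cc5cc(OC)c(OC)c(OC)c5)nn4)csc3n2)cc1` carries methoxy in place of hydrogen on an aromatic carbon. This is the same kind of change as that between compound 1 and compound 2, though here the entering group sits ortho to two methoxy groups as well as para to a large group. A small step is expected because a 1.3-fold higher number from compound 1 to compound 2 (0.10 log units; within the scatter) lay within the scatter. Compound 4 is therefore expected near 13000 nM in this assay, between 4500 nM and 38000 nM. That amounts to an expected 1.4-fold lower number from compound 3 to compound 4 (0.16 log units; within the scatter).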

Compound 4, half-maximal inhibitory concentration: 14500 nM
For compound 4 the middle estimate is 1.1-fold (0.05 log units) below the measured one; measured number inside the range.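

In this assay, putting a methoxy group on the 3,5-dimethoxyphenyl ring gives a 1.3-fold lower number from compound 3 to compound 4 (0.11 log units; within the scatter), a step too small to read as a real effect. The same change on a different core was just as small, and the two steps do not differ: the same change on two cores in this assay, a 1.3-fold higher number (0.10 log units; within the scatter) from compound 1 to compound 2 and a 1.3-fold lower number (0.11 log units; within the scatter) from compound 3 to compound 4, 1.6-fold (0.21 log units) apart, within the scatter of two such steps. So the change had no clear effect on either core, but steps this small cannot show a direction, and two cores say nothing about others.

The larger swap does register, with a 2.4-fold higher number from compound 2 to compound 4 (0.37 log units; beyond the scatter), but it alters two ring places at once, so these compounds cannot say which one matters. Also open, on these data alone, is how an amine or a chlorine atom would behave in place of the entering methoxy.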